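A few compounds are considered here, and "the series" means these few. Any claim that something is new, unique, unknown or untested is made for them only; others in the source may bear on it.

Working notes on the series.

In an assay on isolated protein for inhibition of aldehyde dehydrogenase 1A1 (Homo sapiens), read by spectrophotometry, tested at 10 uM (on this read-out lower numbers stand for less inhibition and higher numbers for more inhibition at the one concentration tested (going by the name of the read-out)), compound 1 `CC(C)=CCn1c(CN2CCN(C(=O)C3CC3)CC2)nc2ccccc21` gives 74.3%. Compound 2 `Cc1cccc(Cn2c(CN3CCN(C(=O)c4cccnc4)CC3)nc3ccccc32)c1` gives 24.5% in the same read-out, and compound 3 `Cc1cccc(Cn2c(CN3CCN(C(=O)CC(C)C)CC3)nc3ccccc32)c1` gives 71.4%. Compound 3 stands second highest of the three numbers: the gap to compound 1 lies within the scatter, while the gap to compound 2 lies beyond it.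

Among the compounds with values here, the one step with a single change is a number 46.9 percentage points higher from compound 2 to compound 3 (beyond the scatter), a large gain when an open chain replaces an aromatic ring on the carbonyl carbon.

Compound 4 `Cc1cccc(Cn2c(CN3CCN(C(=O)c4ccc(Cl)cc4)CC3)nc3ccccc32)c1` differs from compound 3 by 4-chlorophenyl in place of isobutyl on a carbonyl carbon. This change runs the other way round to the step from compound 2 to compound 3: an aromatic ring again enters on the carbonyl carbon in place of isobutyl. The ring here is carbon only with a chlorine on it, not the pyridin-3-yl of compound 2, so the earlier step is a guide only in direction. A loss beyond the scatter is expected for compound 4, with the step estimated as a number 31.4 percentage points lower from compound 3 to compound 4 (beyond the scatter). The estimate for compound 4 in this assay is 40%, in the range 15% to 65%.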

Compound 4, a percentage reported as inhibition, at one concentration (the size of the read-out at that concentration, not a potency): 23.2%
The estimate for compound 4 lay 16.8 percentage points above the measured number; measured number inside the range.
By their numbers in this assay, from the lowest: compounds 4 and 2 (each within the scatter of the next); then compounds 3 and 1 (each within the scatter of the next).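

At the carbonyl carbon, this assay now records a number 48.2 percentage points lower from compound 3 to compound 4 (beyond the scatter) when 4-chlorophenyl takes the place of isobutyl, so a large loss is no longer confined to pyridin-3-yl, and a ring nitrogen is not required for it among these compounds. The two aromatic groups can also be compared directly, and the record reads a number 1.3 percentage points lower from compound 2 to compound 4 (within the scatter), so this read-out does not separate the six-membered aromatic ring of carbon only, with its chlorine, from pyridin-3-yl, while compound 3, with open-chain isobutyl, stands well clear of both. No measurement at hand bears on the reason for this difference between the open chain and the two aromatic groups.

Still open, from the compounds shown here alone, is whether the low numbers belong to aromatic rings as such, which a plain phenyl, without chlorine, and a saturated cyclohexyl on the same carbonyl carbon would help to settle. Also open, going by these compounds, is how far the open-chain side extends, for instance to a longer chain such as n-hexyl or to a chain ending in an amine, and whether the gaps seen at the one tested concentration would carry over to full potency values.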